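Methoxy to fluoro on the ortho-substituted phenyl arm

The compounds below may be only part of what the source reports. "The series", "measured", "known", "first", "only" and "open" are said of these compounds alone.

Measured so far in a functional assay on SF-539 cells (Homo sapiens) for inhibition, read by sulforhodamine B assay, with a stated time of 48 h, tested at 10 uM; on this read-out higher numbers stand for more inhibition at the one concentration tested (going by the name of the read-out) and lower numbers for less inhibition:
compound 1, `c1ccc(-c2cn3ccnc3c(-c3ccc4ncn(C5CCCCC5)c4c3)n2)cc1`: 27.8%
compound 2, `COc1ccc(-c2cn3ccnc3c(-c3ccc4ncn(C5CCCCC5)c4c3)n2)cc1`: -43.4%
compound 3, `COc1ccccc1-c1cn2ccnc2c(-c2ccc3ncn(C4CCCCC4)c3c2)n1`: 8.07%

Compound 3 holds the second highest of the three numbers. Its two neighbours are set by measured steps: a number 19.7 percentage points lower from compound 1 to compound 3 (beyond the scatter), and a number 51.5 percentage points higher from compound 2 to compound 3 (beyond the scatter). Both steps lie beyond the scatter, so compound 3 sits clearly under compound 1 and clearly over compound 2.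

Compound 4, `Fc1ccccc1-c1cn2ccnc2c(-c2ccc3ncn(C4CCCCC4)c3c2)n1`, is the next entry. It differs from compound 3 by fluoro in place of methoxy on an aromatic carbon.

For the measured compounds named here, no measured step exchanges methoxy for fluoro anywhere, so the expectation rests on indirect evidence. The step of a number 19.7 percentage points lower from compound 1 to compound 3 (beyond the scatter) shows what methoxy at this very position costs relative to hydrogen, and a number 71.2 percentage points lower from compound 1 to compound 2 (beyond the scatter) shows a far larger cost when methoxy enters at the other position of the same ring. Fluoro, one heavy atom without an acceptor, stands between hydrogen and methoxy in what is counted, so compound 4 is expected to land between compound 3 and compound 1, a step of a number 9.9 percentage points higher from compound 3 to compound 4 (within the scatter) that need not clear the scatter. The estimate for compound 4 in this assay is 18%, with a range from -10% to 42%.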

Compound 4, a percentage reported as inhibition, at one concentration (the size of the read-out at that concentration, not a potency): 4.51%
For compound 4 the middle estimate is 13.5 percentage points above the measured one, and the stated range covers the measured number.
By their numbers in this assay, from the lowest: compound 2; then compounds 4 and 3 (each within the scatter of the next); then compound 1.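

In this assay, the change from 2-methoxyphenyl to 2-fluorophenyl ortho to a large group gives a number 3.6 percentage points lower from compound 3 to compound 4 (within the scatter), so this read-out does not separate the two groups at this place, even though methoxy has more heavy atoms and a hydrogen-bond acceptor that fluoro lacks. The hydrogen comparison now has a second case: a number 23.3 percentage points lower from compound 1 to compound 4 (beyond the scatter), so among the groups shown at this place, the drop from hydrogen is not confined to methoxy. The other comparison, a number 47.9 percentage points higher from compound 2 to compound 4 (beyond the scatter), shows that compound 2 lies well under compound 4 as well as under compound 3, which sets the 4-methoxyphenyl arm apart from both ortho-substituted arms in this small set.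

Still open, as far as these compounds go, is whether an amine, a carboxylic acid or a longer chain such as propoxy at this place would read like compound 3 and compound 4 or would come closer to compound 1, and how these single-concentration numbers relate to potency. Nothing on hand accounts for any of these steps.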